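A few compounds are considered here, and "the series" means these few. Any claim that something is new, unique, unknown or untested is made for them only; others in the source may bear on it.

In a functional assay on MDA-MB-231 cells (Homo sapiens) for antiproliferative activity, read by MTT assay, with a stated time of 72 h (a higher number here means a weaker inhibitor, a lower number a stronger inhibitor), compound 1 (`NC1=NC2(CCSCC2)N(OCCCOc2cccc(Cl)c2)C(N)=N1`) gives 130 nM, the lowest of three numbers, against compound 2 (`NC1=NC2(CCOCC2)N(OCCCOc2ccccc2Cl)C(N)=N1`) at 1430 nM and compound 3 (`Cc1cc(C)cc(OCCCON2C(N)=NC(N)=NC23CCOCC3)c1`) at 3570 nM. Compound 4 (`NC1=NC2(CCSCC2)N(OCCCOc2cc(Cl)c(Cl)cc2Cl)C(N)=N1`) keeps the core of compound 1 and carries 2,4,5-trichlorophenyl in place of 3-chlorophenyl on an oxygen on a saturated carbon. For the measured compounds named here, only one measured step swaps a group at this place, a 2.5-fold higher number from compound 2 to compound 3 (0.40 log units; beyond the scatter), which is modest, and it involves different groups, so it bears on this change only loosely. A modest step toward a higher number is expected in this assay, the expected step being a 2.3-fold higher number from compound 1 to compound 4 (0.36 log units; beyond the scatter). Compound 4 is estimated at 300 nM, with an expected range of 80 nM to 1000 nM.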

Compound 4, half-maximal inhibitory concentration: 110 nM
Estimate against measurement, compound 4: 2.7-fold (0.44 log units) above; measured number inside the range.
By their numbers in this assay, from the lowest: compounds 4 and 1 (each within the scatter of the next); then compound 2; then compound 3.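

On the core of compound 1 in this assay, 2,4,5-trichlorophenyl in place of 3-chlorophenyl gives a 1.2-fold lower number from compound 1 to compound 4 (0.07 log units; within the scatter), so this place on the core of compound 1 takes the trichlorinated ring with no readable change. For the compounds shown here, the only earlier swap at this place, a 2.5-fold higher number from compound 2 to compound 3 (0.40 log units; beyond the scatter), lies on a different core and beyond the scatter. Nothing available here explains the result.

Open, going by these compounds, is whether an amine or a carboxylic acid on this phenyl ring would hold the number. On these data alone, the effect of a longer chain in place of the present linker is also open.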